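From 4-chlorophenyl to 4-cyanophenyl: expectation for compound 4

This account rests on a few compounds, and the source may have more. Where it says the series, first, only, none or still open, it means among the compounds named here.

In an ADME assay on Vero cells (Chlorocebus sabaeus) for cytotoxicity, read by MTT assay, with a stated time of 72 h (on this read-out higher numbers stand for lower toxicity in this test and lower numbers for higher toxicity in this test), compound 1 `CC1(C)C=Cc2c(ccc(C(=O)/C=C/c3ccc(Cl)cc3)c2O)O1` gives 92200 nM, compound 2 `CC1(C)C=Cc2c(ccc(C(=O)/C=C/c3ccc(Cl)c(Cl)c3)c2O)O1` gives 142000 nM and compound 3 `CC1(C)C=Cc2c(ccc(C(=O)/C=C/c3ccc(Cl)cc3Cl)c2O)O1` gives 131000 nM. Compound 1 is therefore not separated from either neighbour. Compound 4 `CC1(C)C=Cc2c(ccc(C(=O)/C=C/c3ccc(C#N)cc3)c2O)O1` differs from compound 1 as follows: cyano in place of chloro on an aromatic carbon. In words, this is cyano in place of chloro on an aromatic carbon. Among the measured compounds shown here, no measured step makes this exchange. The closest evidence is the addition of chloro, a 1.5-fold higher number from compound 1 to compound 2 (0.19 log units; within the scatter) and a 1.4-fold higher number from compound 1 to compound 3 (0.15 log units; within the scatter), together with the shift of chloro in a 1.1-fold lower number from compound 2 to compound 3 (0.04 log units; within the scatter). All three lie within the scatter, so no step beyond the scatter is expected in this assay. The estimated step is a 1.1-fold higher number from compound 1 to compound 4 (0.04 log units; within the scatter). Compound 4 is expected at 100000 nM, with an estimated range of 50000 nM to 190000 nM.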

Compound 4, half-maximal cytotoxic concentration: 80200 nM
Compound 4: middle estimate off by 1.2-fold (0.10 log units), on the high side, and the stated range covers the measured number.
By their numbers in this assay, from the lowest: compounds 4, 1, 3 and 2 (each within the scatter of the next).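

In this assay, cyano in place of chloro at this position, para to a large group, stays within the scatter (a 1.1-fold lower number from compound 1 to compound 4 (0.06 log units; within the scatter)). The comparisons with the dichlorophenyl compounds also stay within it (a 1.6-fold lower number from compound 3 to compound 4 (0.21 log units; within the scatter); a 1.8-fold lower number from compound 2 to compound 4 (0.25 log units; within the scatter)), so a group other than chloro now gives a number not separated from those of the three chlorinated compounds. No measurement shown accounts for these values. Going by these compounds, whether an amine or a carboxylic acid here would separate from compound 1 remains open. So does whether any exchange at this position goes beyond the scatter.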